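Putting sulfur into the acid chain

The compounds below may be only part of what the source reports. "The series", "measured", "known", "first", "only" and "open" are said of these compounds alone.

In a functional assay for inhibition, with Homo sapiens as the target (on this read-out higher numbers stand for weaker inhibition and lower numbers for stronger inhibition), compound 3 `O=C(O)CCCCCCCCCCn1nc(-c2ccccc2)c(-c2ccccc2)c1-c1ccccc1` gives 18600 nM as the higher of the two actual numbers in this small set. Compound 2 `O=C(O)CCCCCCCn1nc(-c2ccccc2)c(-c2ccccc2)c1-c1ccccc1` is nearest to it and gives 3400 nM in the same read-out. Compound 1 `O=C(O)CCCCCn1nc(-c2ccccc2)c(-c2ccccc2)c1-c1ccccc1` gives > 78000 nM as a limit of the assay and not a number.

Compound 4 `O=C(O)C[S+]([O-])CCCCCCn1nc(-c2ccccc2)c(-c2ccccc2)c1-c1ccccc1` keeps the shared core and differs from compound 3 only in the chain: a group of 6 heavy atoms (2 carbon, 3 oxygen, 1 sulfur; no ring) in place of a group of 7 heavy atoms (5 carbon, 2 oxygen; no ring), on a saturated chain carbon, six bonds along the chain from an aromatic nitrogen is the whole of the change. The measured steps that bear on it all alter chain length. They show an at least 22-fold lower number from compound 1 to compound 2 (1.36 log units; beyond the scatter) and then a 5.5-fold higher number from compound 2 to compound 3 (0.74 log units; beyond the scatter) as the chain grows, while the overall change is an at least 4.1-fold lower number from compound 1 to compound 3 (0.62 log units; beyond the scatter) across the set. Among the compounds with values here, no measured step tests sulfur in the chain, so that part of the change remains open.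

The chain of compound 4 is shorter than that of compound 3 and longer than that of compound 2, so a modest move towards the 3400 nM of compound 2 is expected. The expected step is a 2.7-fold lower number from compound 3 to compound 4 (0.42 log units; beyond the scatter) in this assay and is no more than an estimate. For compound 4 the estimated value is 7000 nM with an expected range from 1800 nM to 28000 nM in this read-out.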

Compound 4, half-maximal inhibitory concentration: 6500 nM
Compound 4: middle estimate off by 1.1-fold (0.03 log units), on the high side, and the stated range covers the measured number.
By their numbers in this assay, from the lowest: compounds 2 and 4 (each within the scatter of the next); then compound 3. At a limit, above all of these: compound 1.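

In this assay, the new chain, placed on a saturated chain carbon, six bonds along the chain from an aromatic nitrogen, gives the first measured result for sulfur and its oxygen in this chain, and the step is a 2.9-fold lower number from compound 3 to compound 4 (0.46 log units; beyond the scatter). The comparison with the shorter all-carbon acid reads a 1.9-fold higher number from compound 2 to compound 4 (0.28 log units; within the scatter), so these two values cannot be told apart and the chain containing sulfur holds up as well as the best all-carbon chain shown. The step from the shortest chain, an at least 12-fold lower number from compound 1 to compound 4 (1.07 log units; beyond the scatter), is large but rests on a limit of the assay and not a number: the limit of > 78000 nM in this assay, at which 1 of the 4 values shown sits.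

As far as these compounds go, what the sulfur and its oxygen contribute apart from chain length stays open, as an all-carbon chain of matching length, a plain thioether or a sulfone at this place would be needed to separate the two. Also open, from the compounds shown here alone, is whether the carboxylic acid at the chain end is required, which an amide or a tetrazole there would test.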